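The compounds below may be only part of what the source reports. "The series", "measured", "known", "first", "only" and "open" are said of these compounds alone.

Working notes on the series. In a functional assay on RT-112 cells (Homo sapiens) for antiproliferative activity, read by MTT assay, with a stated time of 72 h (on this read-out lower numbers stand for stronger inhibition of growth and higher numbers for weaker inhibition of growth), compound 1 (`COc1cc(Nc2ncnc3c(NC(=O)Nc4cccc(Cl)c4Cl)cccc23)cc(OC)c1`) gives 63.2 nM, compound 2 (`COc1cc(Nc2ncnc3c(NC(=O)Nc4cc(Cl)c(Cl)cc4Cl)cccc23)cc(OC)c1`) gives 4890 nM, and compound 3 (`COc1cc(Nc2ncnc3c(NC(=O)Nc4cc(F)cc(F)c4)cccc23)cc(OC)c1`) gives 2630 nM. Compound 3 stands level with compound 2, as the measured step is a 1.9-fold lower number from compound 2 to compound 3 (0.27 log units; within the scatter). The gap to compound 1 is large, at a 42-fold higher number from compound 1 to compound 3 (1.62 log units; beyond the scatter).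

The next change leads to compound 4 (`COc1cc(Nc2ncnc3c(NC(=O)Nc4ccc(Cl)cc4)cccc23)cc(OC)c1`), with 4-chlorophenyl in place of 3,5-difluorophenyl on an amide-type nitrogen.

All three measured steps concern this same place. The two large ones both start from the 2,3-dichlorophenyl of compound 1: a 77-fold higher number from compound 1 to compound 2 (1.89 log units; beyond the scatter) and a 42-fold higher number from compound 1 to compound 3 (1.62 log units; beyond the scatter). Among the three measured compounds, only compound 1 stands apart, and compound 2 shows that a chlorinated ring need not give a low number. The 4-chlorophenyl of compound 4 is not the group carried by compound 1, so the closer guide is the step of a 1.9-fold lower number from compound 2 to compound 3 (0.27 log units; within the scatter). No step beyond the scatter is therefore expected in this assay, although a large drop towards compound 1 cannot be excluded. The expected step is a 1.8-fold lower number from compound 3 to compound 4 (0.24 log units; within the scatter). For compound 4 the estimated value is 1500 nM, with an expected range from 300 nM to 6000 nM.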

Compound 4, concentration for 50% growth inhibition: 2490 nM
Compound 4: middle estimate off by 1.7-fold (0.22 log units), on the low side; the measured number falls inside the stated range.
By their numbers in this assay, from the lowest: compound 1; then compounds 4, 3 and 2 (each within the scatter of the next).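

In this assay the 4-chlorophenyl on the amide-type nitrogen stands level with the 3,5-difluorophenyl, with a 1.1-fold lower number from compound 3 to compound 4 (0.02 log units; within the scatter), and also with the 2,4,5-trichlorophenyl, with a 2.0-fold lower number from compound 2 to compound 4 (0.29 log units; within the scatter), so three differently substituted phenyl groups now sit together within the scatter. The step from the 2,3-dichlorophenyl, a 39-fold higher number from compound 1 to compound 4 (1.60 log units; beyond the scatter), shows that a single chlorine on the ring does not give a number near that of compound 1, which is the one exception among the four compounds and the only one that stands apart from the other three. Nothing at hand bears on the reason for this result.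

The compounds shown leave open whether the low number of compound 1 needs both chlorines of the 2,3-dichlorophenyl, which a 2-chlorophenyl or a 3-chlorophenyl group at this nitrogen would help to settle. They also leave open how this assay responds at the same position to a ring that carries no halogen, such as an unsubstituted phenyl, or to one bearing an amine or a carboxylic acid.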